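This account rests on a few compounds, and the source may have more. Where it says the series, first, only, none or still open, it means among the compounds named here.

Of the compounds shown here, three built on one shared core have been tested in a functional assay on the whole organism (strain CD1) for inhibition, with Mus musculus as the target, with stated times of 15 min and 20 min, at a dose of 10 mg/kg by the subcutaneous route; on this read-out lower numbers stand for less inhibition and higher numbers for more inhibition at the one dose given (going by the name of the read-out). Compound 1, `CCOC(=O)/C(C#N)=C/c1ccoc1`, gives 55.9%. Compound 2, `CC(C)(C)OC(=O)/C(C#N)=C/c1ccoc1`, gives 81.8% in this assay, and compound 3, `CCNC(=O)/C(C#N)=C/c1ccoc1`, gives 31%. Compound 3 therefore stands lowest of the three numbers: its nearest neighbour is compound 1, and the step of a number 24.9 percentage points lower from compound 1 to compound 3 (beyond the scatter) lies beyond the scatter, while the step of a number 50.8 percentage points lower from compound 2 to compound 3 (beyond the scatter) is large. In the other direction, the step of a number 25.9 percentage points higher from compound 1 to compound 2 (beyond the scatter) shows that a larger group on the oxygen carried the number upward by a modest amount.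

Compound 4, `N#C/C(=C\c1ccoc1)C(=O)Nc1ccccc1`, differs from compound 3 by phenyl in place of ethyl on an amide-type nitrogen. Among the compounds with values here, none of the measured steps alters the group on the amide-type nitrogen, so no step bears on this change directly. The only loose comparison is the step of a number 25.9 percentage points higher from compound 1 to compound 2 (beyond the scatter), in which a larger group replacing ethyl raised inhibition; whether a larger group on the amide-type nitrogen behaves the same way is not shown by these data. Compound 4 is therefore expected to give 45%, with a range from 20% to 70%. The expected step of a number 14 percentage points higher from compound 3 to compound 4 (beyond the scatter) is a modest rise, though a result within the scatter would not be surprising.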

Compound 4, a percentage reported as inhibition, in the whole organism at one dose (the size of the read-out at that dose, not a potency): 48%
Compound 4: middle estimate off by 3 percentage points, on the low side; measured number inside the range.
By their numbers in this assay, from the lowest: compound 3; then compounds 4 and 1 (each within the scatter of the next); then compound 2.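

Within the data shown here, with a number 17 percentage points higher from compound 3 to compound 4 (beyond the scatter) in this assay, the group on the amide-type nitrogen is seen for the first time to matter: phenyl, with its six-membered aromatic ring of carbon only and 6 heavy atoms, goes with more inhibition than ethyl, with 2 heavy atoms. The earlier steps shown here changed only the group on the oxygen or put ethylamino in place of ethoxy or tert-butoxy on the carbonyl carbon, and so left this nitrogen's group unexplored. Nothing given here explains why the phenyl compound reads higher than the ethyl compound.

The compounds shown leave open whether the rise follows the aromatic ring or simply the larger group, a question that a cyclohexyl, benzyl or tert-butyl group on the same nitrogen would bear on. Also open, from the compounds shown here alone, is how this assay would respond to an amine or a carboxylic acid on the phenyl ring, or to a longer chain than ethyl on the amide-type nitrogen.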